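Trifluoromethyl to nitro in a series with little spread

This account rests on a few compounds, and the source may have more. Where it says the series, first, only, none or still open, it means among the compounds named here.

Compound 1 (`O=C(Nc1ccc(S(=O)(=O)Nc2cc(F)c(O)c(F)c2)cc1)c1ccccc1`): 68600 nM
Compound 2 (`O=S(=O)(Nc1cc(F)c(O)c(F)c1)c1ccc(N2CCCC2)cc1`): 97100 nM
Compound 3 (`O=S(=O)(Nc1cc(F)c(O)c(F)c1)c1ccc(C(F)(F)F)cc1`): 66000 nM

These three values in a functional assay for inhibition (on this read-out lower numbers stand for stronger inhibition and higher numbers for weaker inhibition), cannot be told apart, with a 1.0-fold lower number from compound 1 to compound 3 (0.02 log units; within the scatter) and a 1.5-fold lower number from compound 2 to compound 3 (0.17 log units; within the scatter) as the gaps that place compound 3 among them. Compound 4 (`O=[N+]([O-])c1ccc(S(=O)(=O)Nc2cc(F)c(O)c(F)c2)cc1`) carries nitro in place of trifluoromethyl on an aromatic carbon, para to a large group (nitro in place of trifluoromethyl on an aromatic carbon). Within the data shown here, no measured step tests nitro itself. The closest evidence is earlier change at that same carbon, which gave a 1.4-fold higher number from compound 1 to compound 2 (0.15 log units; within the scatter) and the two gaps above, all within the scatter. No step beyond the scatter is therefore expected in this assay, and the estimated step is a 1.1-fold higher number from compound 3 to compound 4 (0.03 log units; within the scatter) and no more. For compound 4 the estimated value is 70000 nM (35000 nM to 140000 nM).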

Compound 4, half-maximal inhibitory concentration: 45700 nM
Beside the measured number, compound 4's estimate is 1.5-fold (0.19 log units) above it; low and high end bracket the measured number.
By their numbers in this assay, from the lowest: compounds 4, 3, 1 and 2 (each within the scatter of the next, the first and the last beyond it).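

In this assay, among these compounds, nitro at this carbon gives the first step beyond the scatter, a 2.1-fold lower number from compound 2 to compound 4 (0.33 log units; beyond the scatter) and still modest in size. Nitro cannot be told apart from trifluoromethyl or benzamido, with a 1.4-fold lower number from compound 3 to compound 4 (0.16 log units; within the scatter) and a 1.5-fold lower number from compound 1 to compound 4 (0.18 log units; within the scatter) as the gaps, so only the pyrrolidin-1-yl comparison separates. No measurement shown here accounts for that one separated step. Going by these compounds, whether an amine, a carboxylic acid or a nitrile at this same carbon would move the number further stays open.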